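From 2-ethylphenyl to 3-methylphenyl: an untested swap

This account rests on a few compounds, and the source may have more. Where it says the series, first, only, none or still open, it means among the compounds named here.

Of the compounds shown here, three have been measured in a functional assay on MCF7 cells (Homo sapiens) for antiproliferative activity, read by sulforhodamine B assay, with a stated time of 48 h; on this read-out higher numbers stand for weaker inhibition and lower numbers for stronger inhibition. Compound 1 `CCc1ccccc1OS(=O)(=O)c1ccc(N2CCN(C)C2=O)cc1` gives 26000 nM, compound 2 `Cc1ccc(OS(=O)(=O)c2ccc(N3CCN(C)C3=O)cc2)c(C)c1` gives 2500 nM, and compound 3 `CCCN1CCN(c2ccc(S(=O)(=O)Oc3ccccc3CC)cc2)C1=O` gives 2300 nM. Compound 3 therefore carries the lowest number of the three, but its value and that of compound 2 lie within the scatter of each other, and both sit well under the value of compound 1.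

Compound 4 `CCCN1CCN(c2ccc(S(=O)(=O)Oc3cccc(C)c3)cc2)C1=O` keeps the rest of compound 3 and puts 3-methylphenyl in place of 2-ethylphenyl on an oxygen. The nearest guide is a 10-fold lower number from compound 1 to compound 2 (1.02 log units; beyond the scatter), a large step seen when 2,4-dimethylphenyl replaced 2-ethylphenyl on that same oxygen. An equally large step, an 11-fold lower number from compound 1 to compound 3 (1.05 log units; beyond the scatter), came from a change elsewhere in the molecule, and compound 3 already carries that change. Among the measured compounds shown here, no measured compound holds 3-methylphenyl, and no measured pair shows how a swap on the oxygen behaves once that other change is in place. The direction is therefore open, and the expected change in this assay is a 1.1-fold higher number from compound 3 to compound 4 (0.04 log units; within the scatter), which means no step beyond the scatter. Compound 4 is estimated at 2500 nM, with an expected range from 600 nM to 10000 nM.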

Compound 4, half-maximal inhibitory concentration: 86000 nM
Beside the measured number, compound 4's estimate is 34-fold (1.54 log units) below it; the whole stated range lies below it.
By their numbers in this assay, from the lowest: compounds 3 and 2 (each within the scatter of the next); then compound 1; then compound 4.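

In this assay, among the compounds shown here, 3-methylphenyl in place of 2-ethylphenyl gives a 37-fold higher number from compound 3 to compound 4 (1.57 log units; beyond the scatter), whereas the only earlier swap on this oxygen gave a 10-fold lower number from compound 1 to compound 2 (1.02 log units; beyond the scatter), so changes to the group here can move the number a long way in either direction. The result also shows that a small change can matter greatly at this position: both groups have one six-membered aromatic ring of carbon only, no hydrogen-bond donors or acceptors and no net charge, and they differ in size by only 8 heavy atoms against 7. Nothing available here accounts for the size of this step.

The compounds shown do not separate the effect of losing the ethyl group from that of gaining the methyl group, and plain phenyl on the same oxygen would be a simple way to begin telling them apart. On these data alone, it also remains open whether 3-methylphenyl would give a step of this size on the core of compound 1, which has a different group on the ring nitrogen.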